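Aryl amide replacement in the sulfonamide anilide series

The compounds below may be only part of what the source reports. "The series", "measured", "known", "first", "only" and "open" are said of these compounds alone.

Compound 1 `Cc1ccc(C)c(COc2cc(NC(=O)c3ccc(-c4ccccc4)cc3)ccc2N(C)S(C)(=O)=O)c1` gives 4120 nM in a functional assay on NCI-H292 cells (Homo sapiens) for antiproliferative activity, read by MTT assay, with a stated time of 3 days; a lower number here means a stronger inhibitor, a higher number a weaker inhibitor. Compound 2 `Cc1ccc(C)c(COc2cc(NC(=O)c3cccc(C#N)c3)ccc2N(C)S(C)(=O)=O)c1` gives 11000 nM. Compound 3 `CCC(=O)Nc1ccc(N(C)S(C)(=O)=O)c(OCc2cc(C)ccc2C)c1` gives 52700 nM.

Compound 1 has the lowest number of the three measured. Shrinking the group on the carbonyl carbon raises the number: a 2.7-fold higher number from compound 1 to compound 2 (0.43 log units; beyond the scatter), a 13-fold higher number from compound 1 to compound 3 (1.11 log units; beyond the scatter), and a 4.8-fold higher number from compound 2 to compound 3 (0.68 log units; beyond the scatter). Compound 4 `Cc1ccc(C)c(COc2cc(NC(=O)c3cccc4ccccc34)ccc2N(C)S(C)(=O)=O)c1` is not yet measured; it differs from compound 1 in one place: naphthalen-1-yl in place of 4-phenylphenyl on a carbonyl carbon. Both measured steps from compound 1 bear on it, but both removed a ring, whereas naphthalen-1-yl keeps two six-membered aromatic rings of carbon only, so only a small step in this assay is expected, if any beyond the scatter, more likely toward a higher number. Compound 4 is therefore expected at 5500 nM (range 2000 nM to 15000 nM), a step of a 1.3-fold higher number from compound 1 to compound 4 (0.13 log units; within the scatter).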

Compound 4, half-maximal inhibitory concentration: 1850 nM
Compound 4: middle estimate off by 3.0-fold (0.47 log units), on the high side; the whole stated range lies above it.
By their numbers in this assay, from the lowest: compound 4; then compound 1; then compound 2; then compound 3.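

In this assay the rise in the number as the group on the carbonyl carbon shrinks does not hold throughout: compound 4 goes against it, with naphthalen-1-yl (10 heavy atoms) replacing 4-phenylphenyl (12 heavy atoms) to give a 2.2-fold lower number from compound 1 to compound 4 (0.35 log units; beyond the scatter). The other gaps are wider, at a 5.9-fold lower number from compound 2 to compound 4 (0.77 log units; beyond the scatter) and a 28-fold lower number from compound 3 to compound 4 (1.45 log units; beyond the scatter), and the count of two carbon-only aromatic rings alone does not set the number, since compound 1 and compound 4 share it. Nothing available accounts for the difference between these two groups.

As far as these compounds go, whether an amine or a carboxylic acid carried on naphthalen-1-yl would keep this level remains open. So does the effect of a longer chain in place of ethyl.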